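Benzyl in place of phenyl: notes on compound 3

A few compounds are considered here, and "the series" means these few. Any claim that something is new, unique, unknown or untested is made for them only; others in the source may bear on it.

Measured in an ADME assay on microsomes from liver (Rattus norvegicus) for metabolic stability; a higher number here means that the compound lasts longer, a lower number that the compound disappears faster:
- compound 1 `O=C1NC(=O)/C(=C/C(c2ccc(-c3ccc4cccc(F)c4c3)[nH]c2=O)C2CCCCC2)O1`: 2.39 h
- compound 2 `O=C1NC(=O)/C(=C/C(c2ccccc2)c2ccc(-c3ccc4cccc(F)c4c3)[nH]c2=O)O1`: > 3 h

Compound 2 gives > 3 h, which is a limit of this assay and not a number. For the measured compounds named here, the series so far has (the limit of > 3 h in this assay, at which 1 of the 2 values shown sits).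

The next structure is compound 3 `O=C1NC(=O)/C(=C/C(Cc2ccccc2)c2ccc(-c3ccc4cccc(F)c4c3)[nH]c2=O)O1`, with the change (benzyl in place of phenyl on a saturated chain carbon bound to an aromatic carbon and a double-bonded chain carbon). Going by the values given here, the one measured step at this saturated chain carbon is an at least 1.2-fold higher number from compound 1 to compound 2 (0.09 log units; that floor lies within the scatter). Among the compounds with values here, that step exchanges cyclohexyl for phenyl, so it bears on benzyl only loosely, and no measured step covers benzyl itself. Within the data shown here, with only that step as a guide, no change beyond the scatter is expected in this assay, and no direction is favoured. The expected size is an at least 1.0-fold lower number from compound 2 to compound 3 (0.02 log units; that floor lies within the scatter). For compound 3 the estimated half-life is 2.8 h, with an expected range of 1.5 h to 5 h.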

Compound 3, half-life in the Rattus norvegicus assay: 2.96 h
The estimate for compound 3 lay 1.1-fold (0.02 log units) below the measured number, and the stated range covers the measured number.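

In the Rattus norvegicus assay, compound 1 gives 2.39 h and compound 3 gives 2.96 h. In the Rattus norvegicus assay, benzyl on this saturated chain carbon gives a measured step against cyclohexyl: a 1.2-fold higher number from compound 1 to compound 3 (0.09 log units; within the scatter), so the two groups cannot be told apart here. The value of compound 2, > 3 h, is a limit of the assay and not a number. The change from phenyl to benzyl therefore reads only as a floor in the Rattus norvegicus assay, an at least 1.0-fold lower number from compound 2 to compound 3 (0.00 log units; that floor lies within the scatter), whereas a physicochemical assay for solubility, in phosphate buffer, measured as kinetic solubility (a lower number here means a less soluble compound, a higher number a more soluble compound), gives a full step, a 3.6-fold lower number from compound 2 to compound 3 (0.56 log units; beyond the scatter). In the physicochemical assay, compound 2 gives 32800 nM and compound 3 gives 9100 nM.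

On these data alone, the true size of the phenyl to benzyl step in half-life stays open. Also open, as far as these compounds go, is how an amine or a longer chain in place of benzyl on this saturated chain carbon would read in the Rattus norvegicus assay and in the physicochemical assay.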